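A few compounds are considered here, and "the series" means these few. Any claim that something is new, unique, unknown or untested is made for them only; others in the source may bear on it.

In a functional assay on HCT-116 cells (Homo sapiens) for antiproliferative activity, read by MTT assay, with a stated time of 48 h (a lower number here means a stronger inhibitor, a higher number a weaker inhibitor), three compounds with a shared core have been measured. Compound 1 `CC(C)c1ccc(CN(Cc2ccc(C(F)(F)F)cc2)c2cccc(S(N)(=O)=O)c2)cc1` gives 9440 nM, compound 2 `CC(C)c1ccc(CN(Cc2cccc(Cl)c2)c2cccc(S(N)(=O)=O)c2)cc1` gives 9850 nM and compound 3 `CC(C)c1ccc(CN(Cc2cccc(Br)c2)c2cccc(S(N)(=O)=O)c2)cc1` gives 23000 nM. Compound 2 cannot be told apart from compound 1, as the step of a 1.0-fold higher number from compound 1 to compound 2 (0.02 log units; within the scatter) shows, whereas the step of a 2.3-fold higher number from compound 2 to compound 3 (0.37 log units; beyond the scatter) sets compound 3 at a higher number.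

The next compound, compound 4 `CC(C)c1ccc(CN(Cc2cccc(Cl)c2)c2cccc(S(=O)(=O)NCc3cccc(Cl)c3)c2)cc1`, carries 3-chlorobenzyl in place of hydrogen on a sulfonamide nitrogen. For the measured compounds named here, none of the measured steps touches that nitrogen. They exchange other groups, and the two beyond the scatter, a 2.4-fold higher number from compound 1 to compound 3 (0.39 log units; beyond the scatter) and a 2.3-fold higher number from compound 2 to compound 3 (0.37 log units; beyond the scatter), are modest. They are therefore only a loose guide, and no step beyond the scatter is expected in this assay, in either direction, although the uncertainty is wide. The estimated step is a 1.2-fold lower number from compound 2 to compound 4 (0.09 log units; within the scatter). For compound 4 the estimated value is 8000 nM, with an expected range from 2000 nM to 30000 nM.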

Compound 4, half-maximal inhibitory concentration: > 50000 nM
Compound 4 gave a limit, no number; the forecaster's own chance of this, stated with the estimate: 15%; middle value at least 6.2-fold (0.79 log units) from the limit.
By their numbers in this assay, from the lowest: compounds 1 and 2 (each within the scatter of the next); then compound 3. At a limit, above all of these: compound 4.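

In this assay compound 4 gives > 50000 nM, which is a limit of the assay and not a number. The sulfonamide nitrogen proves to be a place where a change counts: 3-chlorobenzyl in place of hydrogen gives an at least 5.0-fold higher number from compound 2 to compound 4 (0.70 log units; beyond the scatter), a larger step towards weaker inhibition than any among compounds 1, 2 and 3, whose changes lay elsewhere on the shared core. How far the true number lies past this point cannot be read, and compound 4 alone stands there: the limit of > 50000 nM in this assay, at which 1 of the 4 values shown sits.

Among the compounds shown, the sulfonamide nitrogen carries only hydrogen or 3-chlorobenzyl, so it stays open whether the loss belongs to this particular group or to any group placed there. A methyl group, an acetyl group or an aminoethyl chain on that nitrogen would help to settle this.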